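Hydroxyazetidine for Dimethylazetidine: An Expected Step

This account rests on a few compounds, and the source may have more. Where it says the series, first, only, none or still open, it means among the compounds named here.

In a functional assay on cells for antagonist activity at Free fatty acid receptor 1 (Homo sapiens), read by TR-FRET and inositol phosphate accumulation, with a stated time of 2 h (on this read-out higher numbers stand for weaker inhibition and lower numbers for stronger inhibition), compound 3 `CC1(C)CN(c2cc(COc3ccc(F)c(F)c3F)nc(-c3ccccn3)n2)C1` gives 25.1 nM, the lowest of the two numbers shown. Compound 2 `Cc1cc(COc2c(F)cc(F)cc2F)nc(-c2ccccn2)n1` gives 1260 nM in this assay, a value that sits well beyond the scatter from compound 3. Compound 1 `CC(=O)Nc1ccc(OCc2cc(C)nc(-c3ccccn3)n2)cc1` is reported only as a limit of this assay, > 39800 nM (the limit of > 39800 nM in this assay, at which 1 of the 3 values shown sits). Compound 4 `OC1CN(c2cc(COc3ccc(F)c(F)c3F)nc(-c3ccccn3)n2)C1` has not yet been measured in this assay; it differs from compound 3 in one place, (3-hydroxyazetidin-1-yl in place of 3,3-dimethylazetidin-1-yl on an aromatic carbon), that is, 3-hydroxyazetidin-1-yl in place of 3,3-dimethylazetidin-1-yl on an aromatic carbon. Among the compounds with values here, no measured pair shows an exchange of this kind, so the step from compound 3 to compound 4 is expected to be a modest weakening, a 3.2-fold higher number from compound 3 to compound 4 (0.50 log units; beyond the scatter), near the edge of the scatter. Compound 4 is accordingly estimated at 80 nM, within 20 nM to 400 nM.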

Compound 4, half-maximal inhibitory concentration: 3160 nM
Compound 4: the middle estimate sits 40-fold (1.60 log units) below what was measured, outside the stated range (above it).
By their numbers in this assay, from the lowest: compound 3; then compound 2; then compound 4. At a limit, above all of these: compound 1.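

Placing 3-hydroxyazetidin-1-yl on this aromatic carbon gives a 130-fold higher number from compound 3 to compound 4 (2.10 log units; beyond the scatter) in this assay, the first exchange shown at this position. The four-membered ring stays, yet the entering group's hydrogen-bond donor, absent from the leaving group, comes with a large loss, so this position does not accept every azetidine alike. Nothing shown gives a cause for the size of this step. The compounds shown leave open how a 3-methoxyazetidin-1-yl group or a 3-aminoazetidin-1-yl group would read here, and whether an unsubstituted azetidine would stay close to compound 3.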